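The source may report more compounds than this note shows. Statements on the series, on what has been measured and on what is new or still open speak of the compounds shown alone.

Compound 1 `CN1Cc2ccc(OCc3ccccc3)cc2[C@@H](O)C1`: in an ADME assay on Vero cells (Chlorocebus sabaeus) for cytotoxicity, read by sulforhodamine B assay, with a stated time of 72 h (a higher number here means a weaker inhibitor, a lower number a stronger inhibitor), compound 1 gives > 100000 nM, which is a limit of the assay rather than a number.
Compound 2 `Cc1ccccc1COc1ccc2c(c1)[C@@H](O)CN(C)C2`: compound 2 gives > 100000 nM, also a limit.
Compound 3 `CN1Cc2ccc(OCCCc3ccccc3)cc2[C@@H](O)C1`: compound 3 gives > 50000 nM, again a limit.

Compound 3 thus stands at a limit, as the other two do; the limit of > 100000 nM in this assay, at which 2 of the 3 values shown sit, and the limit of > 50000 nM in this assay, at which 1 of the 3 values shown sits, are all that is known. Compound 4 `CN1Cc2ccc(OCCC3CCCCC3)cc2[C@@H](O)C1` differs from compound 3 by cyclohexyl in place of benzyl on a saturated chain carbon, two bonds along the chain from an oxygen on an aromatic ring. Among the measured compounds shown here, the one measured step, a step that the two limits leave unreadable from compound 1 to compound 2, cannot be sized, as both of its ends are limits, so no measured step bears on this change, and no shift beyond the scatter in this assay is expected in either direction. Compound 4 is therefore expected to give about 100000 nM, between 40000 nM and 300000 nM, most likely reported again as a limit. The expected step, a step that the limit leaves unreadable from compound 3 to compound 4, lies within the scatter.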

Compound 4, half-maximal inhibitory concentration: > 50000 nM
Compound 4 gave a limit, no number; the forecaster's own chance of this, stated with the estimate: 85%; the middle value does not contradict the limit.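

Compound 4 gives a limit rather than a number, as do compounds 1, 2 and 3, and none of the steps among these compounds can be read. Going by these compounds, what remains open in this assay is the actual half-maximal concentration of each compound, and whether cyclohexyl in place of benzyl changes it at all.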